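From Compound 1 to Compound 4: a Cautious Forecast

This account rests on a few compounds, and the source may have more. Where it says the series, first, only, none or still open, it means among the compounds named here.

Compound 1, `COc1cc(N(C)C(=O)N(C)c2ccc([N+](=O)[O-])cc2)cc(OC)c1OC`: >= 125000 nM
Compound 2, `COc1cc(NC(=O)c2cccc([N+](=O)[O-])c2)cc(OC)c1OC`: >= 125000 nM
Compound 3, `COc1cc(NC(=O)Nc2ccc(F)cc2)cc(OC)c1OC`: 104000 nM

All three compounds were tested in a functional assay on Daoy cells (Homo sapiens) for cytotoxicity, read by MTT assay, with a stated time of 72 h; on this read-out lower numbers stand for stronger inhibition and higher numbers for weaker inhibition. The value for compound 1 is a limit of the measurement rather than a number. The value for compound 2 is also such a limit. Compound 3 gives a number, and it sits close to the limit of >= 125000 nM in this assay, at which 2 of the 3 values shown sit. Compound 1 therefore stands at the weak end of what this measurement can see, with no number of its own to place it more precisely.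

Compound 4, `COc1cc(N(C)C(=O)N(C)c2cccc(F)c2)cc(OC)c1OC`, has not yet been measured. Its difference from compound 1 is 3-fluorophenyl in place of 4-nitrophenyl on an amide-type nitrogen. For the measured compounds named here, because compound 1 only reaches (the limit of >= 125000 nM in this assay, at which 2 of the 3 values shown sit), no measured step shows how this change acts. Going by the values given here, none of the measured compounds shares this exact change either. Compound 3, the one whose structure also holds a fluorine atom, gives 104000 nM, which is a weak number in its own right. The expected step, an at least 1.0-fold lower number from compound 1 to compound 4 (0.01 log units; that floor lies within the scatter), is therefore none beyond the scatter, in either direction. Compound 4 is estimated at 120000 nM, with a likely range from 55000 nM to 260000 nM, and a fair chance that only a limit is reported.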

Compound 4, half-maximal inhibitory concentration: >= 125000 nM
Compound 4 ended at the assay's limit (the forecaster's own chance of this, stated with the estimate: 55%); at least 1.0-fold (0.01 log units) between middle value and limit.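

In this assay compound 4 gives >= 125000 nM, which is a limit and not a number, and compound 1 also stands at a limit, so no step can be read between these two compounds. The compounds shown leave open whether 3-fluorophenyl in place of 4-nitrophenyl on an amide-type nitrogen changes the read-out at all, in either direction.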